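The source may report more compounds than this note shows. Statements on the series, on what has been measured and on what is new or still open speak of the compounds shown alone.

Compound 1, `O=C(Cc1nn(CC(=O)N2CCOCC2)c(=O)c2ccccc12)Nc1ccc(OC(F)(F)F)c(Cl)c1`, gives 30 nM in a functional assay on CHO cells for antagonist activity at sphingosine 1-phosphate receptor 2 (Homo sapiens), read by calcium flux; a higher number here means a weaker inhibitor, a lower number a stronger inhibitor. Compound 2, `CC(C(=O)O)c1nn(Cc2cn3cc(OCC4CC4)c(Cl)cc3n2)c2ccccc2c1=O`, gives 6 nM in this assay. Compound 3, `C[C@@H](C(=O)O)c1nn(Cc2cn3cc(OCC4CC4)c(Cl)cc3n2)c2ccccc2c1=O`, gives 24 nM in this assay.

Among these three numbers compound 3 stands second highest: compound 1 lies within the scatter of it, while compound 2 sits well below it, as the step of a 4.0-fold higher number from compound 2 to compound 3 (0.60 log units; beyond the scatter) shows. That step rests on (the fact that one of compounds 2 and 3 is drawn with a defined configuration and the other without, at the place where they differ), so it tells of configuration at the saturated chain carbon and not of the substituent itself.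

Compound 4, `COC(C(=O)O)c1nn(Cc2cn3cc(OCC4CC4)c(Cl)cc3n2)c2ccccc2c1=O`, differs from compound 3 by carboxy(methoxy)methyl in place of 1-carboxyethyl on an aromatic carbon. Among the measured compounds shown here, no measured step changes this group; the only measured step, from compound 2 to compound 3, alters drawn configuration alone, and compound 4 is drawn without a defined stereocentre at that carbon, as compound 2 is. The evidence therefore gives no direction for the exchange of methyl for methoxy, and the step is expected to be small, within or close to the scatter, with the undefined configuration leaving room for a lower number as seen with compound 2. Compound 4 is estimated at 18 nM in this assay, between 5 nM and 70 nM, a step of a 1.3-fold lower number from compound 3 to compound 4 (0.12 log units; within the scatter) from compound 3.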

Compound 4, half-maximal inhibitory concentration: 23 nM
Estimate against measurement, compound 4: 1.3-fold (0.11 log units) below, and the stated range covers the measured number.
By their numbers in this assay, from the lowest: compound 2; then compounds 4, 3 and 1 (each within the scatter of the next).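

In this assay, among the compounds shown here, the exchange of methoxy for methyl on this saturated chain carbon can now be read with no configuration drawn on either side (a 3.8-fold higher number from compound 2 to compound 4 (0.58 log units; beyond the scatter)), and it is not neutral, which the earlier compounds could not show. The comparison with compound 3 looks flat (a 1.0-fold lower number from compound 3 to compound 4 (0.02 log units; within the scatter)), but it changes the group and the drawn configuration together, as compound 3 has a defined stereocentre at this carbon and compound 4 has none. Compound 4 also shows that an undrawn configuration at this carbon does not by itself go with the lower number of compound 2, as it lies within the scatter of compound 3 and clearly above compound 2.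

The compounds shown leave open how the two separate configurations of compound 4 would compare with each other and with those of the methyl series. They also leave open what other groups on this carbon, such as hydroxy, ethyl or an amine, would do, and whether a primary amide could stand in place of the carboxylic acid.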